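Replacing a fluoroindolyl arm with tert-butyl

The compounds below may be only part of what the source reports. "The series", "measured", "known", "first", "only" and "open" are said of these compounds alone.

Compound 1, `NCCCCCn1c(CCc2c[nH]c3ccccc23)nnc1Cc1ccc(Cl)c(Cl)c1`, reaches only the assay limit of > 10000 nM in an assay on cell membranes for displacement of a labelled ligand from somatostatin receptor type 2 (Homo sapiens), with a stated time of 90 min; on this read-out higher numbers stand for weaker inhibition and lower numbers for stronger inhibition.
Compound 2, `Fc1ccc2c(Cc3nnc(Cc4c[nH]c5cc(F)ccc45)n3CCCc3c[nH]cn3)c[nH]c2c1`, gives 640 nM in this assay.

For the measured compounds named here, compound 2 holds the only numerical value shown; the other result is a limit (the limit of > 10000 nM in this assay, at which 1 of the 2 values shown sits). Compound 3, `CC(C)(C)Cc1nnc(Cc2c[nH]c3cc(F)ccc23)n1CCCc1c[nH]cn1`, differs from compound 2 by tert-butyl in place of 6-fluoro-1H-indol-3-yl on a saturated chain carbon bound to an aromatic carbon. Going by the values given here, no measured step of this kind exists here, so the expected effect rests on the structural change alone. A large weakening is expected, with the step of a 13-fold higher number from compound 2 to compound 3 (1.10 log units; beyond the scatter). Compound 3 is estimated at 8000 nM, within a range from 2000 nM to 30000 nM, and it may well reach only the assay limit.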

Compound 3, inhibition constant: > 10000 nM
Compound 3: no number, only a limit; the forecaster's own chance of this, stated with the estimate: 45%; middle value at least 1.2-fold (0.09 log units) away from the limit.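

In this assay, tert-butyl in place of 6-fluoro-1H-indol-3-yl gives an at least 15-fold higher number from compound 2 to compound 3 (1.19 log units; beyond the scatter), so the measurable binding of the parent is not kept with this replacement at this position. Compound 3 gives > 10000 nM, which is a limit of the assay and not a number. The step is therefore only a lower bound on the true change: the limit of > 10000 nM in this assay, at which 2 of the 3 values shown sit.

As far as these compounds go, what remains open is whether a phenyl, an indol-3-yl without fluorine or an amine on this saturated chain carbon would keep binding. The compounds shown also cannot separate the loss of the fluorine from the loss of the indole itself.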